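Extending the hydrazone arm with a phenylethenyl group

A few compounds are considered here, and "the series" means these few. Any claim that something is new, unique, unknown or untested is made for them only; others in the source may bear on it.

Measured so far:
- compound 1, `O=C(CSc1nnc(-c2ccncc2)n1-c1ccccc1)N/N=C/c1ccccc1`: 18600 nM
- compound 2, `O=C(CSc1nnc(-c2ccncc2)n1-c1ccccc1)N/N=C/c1cc(Br)cc(Br)c1O`: 7590 nM

Both compounds share a core and differ only in the group on the carbon with a double bond to nitrogen. In a functional assay on HepG2 cells (Homo sapiens) for inhibition, read by MTT assay, with a stated time of 48 h (on this read-out lower numbers stand for stronger inhibition and higher numbers for weaker inhibition), compound 1 gives 18600 nM, and compound 2 gives 7590 nM. Within the data shown here, the single measured step, a 2.5-fold lower number from compound 1 to compound 2 (0.39 log units; beyond the scatter), shows that swapping phenyl for 3,5-dibromo-2-hydroxyphenyl lowered the number, so compound 2 holds the lowest number of the two, with compound 1 as its only neighbour.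

Compound 3, `O=C(CSc1nnc(-c2ccncc2)n1-c1ccccc1)N/N=C/C=C/c1ccccc1`, is not yet measured. Its change from compound 2 is 2-phenylethenyl in place of 3,5-dibromo-2-hydroxyphenyl on a carbon with a double bond to nitrogen. The new group carries neither bromine nor a hydroxyl, so it resembles the plain phenyl of compound 1 more than the substituted ring of compound 2. Among the measured compounds shown here, no measured step covers a phenyl-to-phenylethenyl swap, so the only guide is the step of a 2.5-fold lower number from compound 1 to compound 2 (0.39 log units; beyond the scatter), which is expected to be largely undone. The number for compound 3 in this assay is therefore expected to rise, by about a 2.0-fold higher number from compound 2 to compound 3 (0.30 log units; within the scatter). Compound 3 is estimated at 15000 nM, with a range from 5000 nM to 40000 nM.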

Compound 3, half-maximal inhibitory concentration: 8280 nM
Compound 3: middle estimate off by 1.8-fold (0.26 log units), on the high side; the range from low to high includes it.
By their numbers in this assay, from the lowest: compounds 2 and 3 (each within the scatter of the next); then compound 1.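

In this assay, 2-phenylethenyl in place of phenyl gives a 2.2-fold lower number from compound 1 to compound 3 (0.35 log units; beyond the scatter), so this position allows a lower number than the one seen with phenyl without any bromine or hydroxyl on the group. Set against 3,5-dibromo-2-hydroxyphenyl, the same position gives a 1.1-fold higher number from compound 2 to compound 3 (0.04 log units; within the scatter), which means that these two groups cannot be told apart here even though they differ in their atoms and in their hydrogen-bond donors and acceptors. The earlier pair could suggest that the bromines and hydroxyl were needed for the lower number, but 2-phenylethenyl shows that, within these three compounds, a group carrying neither can match it.

No available measurement explains why either group differs from phenyl. Going by these compounds, it also remains open how this assay would read with an amine, a carboxylic acid or a longer carbon chain on the carbon with a double bond to nitrogen, and so whether any such group would move the number beyond the scatter around compound 2 and compound 3.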